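This account rests on a few compounds, and the source may have more. Where it says the series, first, only, none or still open, it means among the compounds named here.

Of the compounds shown here, two of the same core have been measured in a functional assay on MDA-MB-231 cells (Homo sapiens) for cytotoxicity, read by MTT assay, with a stated time of 72 h, tested at 5 uM, in the absence of a further agent; on this read-out higher numbers stand for a weaker effect at the one concentration tested and lower numbers for a stronger effect. Compound 1, `CC1(C)CC(=S)Nc2ccc(Cl)cc21`, gives 94.3% in this assay. Compound 2, `CCNC1=Nc2ccc(Cl)cc2C(C)(C)C1`, gives 85.1% in this assay, the lowest of the two numbers, though its gap to compound 1 lies within the usual scatter, so the two cannot be ranked against each other.

Compound 3, `CCN(CC)CCCNC1=Nc2ccc(Cl)cc2C(C)(C)C1`, has not yet been measured in this assay. It differs from compound 2 in one place: (diethylamino)methyl in place of hydrogen on a saturated chain carbon, two bonds along the chain from an amine nitrogen. Within the data shown here, no measured pair of compounds here shows a step of this kind, so nothing sets its size beforehand.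

The expectation for the step from compound 2 to compound 3 in this assay is a modest lowering of the read-out, a number 13.1 percentage points lower from compound 2 to compound 3 (beyond the scatter), at the edge of what the scatter would hide. Compound 3 is therefore estimated to give 72% in this assay, with a range from 45% to 92%.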

Compound 3, a percentage reported as activity, at one concentration (the size of the read-out at that concentration, not a potency): 36.1%
Compound 3: middle estimate off by 35.9 percentage points, on the high side; measured number below the stated range.
By their numbers in this assay, from the lowest: compound 3; then compounds 2 and 1 (each within the scatter of the next).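

Placing (diethylamino)methyl on a saturated chain carbon, two bonds along the chain from an amine nitrogen, gives a number 49 percentage points lower from compound 2 to compound 3 (beyond the scatter) in this assay. Among these compounds, this is the first change to move the read-out beyond the usual scatter, which shows that this chain position can tolerate a substantial addition and that the addition can strongly alter the result at the one concentration tested. Nothing measured here bears on the reason for a step of this size.

The compounds shown leave open whether the step depends on the added amine nitrogen or on the longer chain alone, a question that a plain hydrocarbon chain of similar length could address. Also open, as far as these compounds go, is how the read-out would respond to piperidine or morpholine in place of the diethylamino group.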